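Bromo in place of dimethylamino in compound 3

The source may hold more compounds than are shown below. What is called first, only, known or untested is meant among the compounds shown, and "the series" means these compounds.

In a functional assay on MGC-803 cells (Homo sapiens) for antiproliferative activity, read by MTT assay, with a stated time of 72 h (on this read-out higher numbers stand for weaker inhibition and lower numbers for stronger inhibition), compound 3 `CCCSc1nc(N/N=C/c2ccc(N(C)C)cc2)c2nnn(Cc3ccccc3)c2n1` gives 13100 nM as its reading. Compound 1 `CCCSc1nc(N/N=C(\C)c2ccc(O)cc2)c2nnn(Cc3ccccc3)c2n1` gives 16700 nM and these two values lie within the scatter of each other. For compound 2 `CCCSc1nc(N/N=C/c2cccs2)c2nnn(Cc3ccccc3)c2n1` the result is > 64000 nM which is a limit of the assay and not a number.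

Compound 4 `CCCSc1nc(N/N=C/c2ccc(Br)cc2)c2nnn(Cc3ccccc3)c2n1` differs from compound 3 on an aromatic carbon of a six-membered aromatic ring of carbon only, para to a large group, where bromo stands in place of dimethylamino (bromo in place of dimethylamino on an aromatic carbon). Among the measured compounds shown here, two measured steps bear on this change only indirectly, namely an at least 3.8-fold higher number from compound 1 to compound 2 (0.58 log units; beyond the scatter) and an at least 4.8-fold lower number from compound 2 to compound 3 (0.68 log units; beyond the scatter) in this assay as well. Each exchanges a whole group, so neither isolates this change. Compound 4 does keep the phenyl ring found in compound 1 (16700 nM) and compound 3 (13100 nM). The expected change is therefore a 1.2-fold higher number from compound 3 to compound 4 (0.09 log units; within the scatter) and no step beyond the scatter is expected. Compound 4 is estimated at 16000 nM with an expected range from 6000 nM to 50000 nM in this read-out.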

Compound 4, half-maximal inhibitory concentration: 34900 nM
Compound 4: the middle estimate sits 2.2-fold (0.34 log units) below what was measured; low and high end bracket the measured number.
By their numbers in this assay, from the lowest: compounds 3 and 1 (each within the scatter of the next); then compound 4. At a limit, above all of these: compound 2.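

In this assay, the group on this aromatic carbon of the phenyl ring proves to matter: with the ring kept, bromo in place of dimethylamino gives a 2.7-fold higher number from compound 3 to compound 4 (0.43 log units; beyond the scatter), so the phenyl ring alone does not set the reading. Compound 4 also separates from compound 1, which had stood within the scatter of compound 3, with a 2.1-fold higher number from compound 1 to compound 4 (0.32 log units; beyond the scatter), although that exchange covers a whole group. Against compound 2, whose reading is a limit of the assay and not a number, the step is only an at least 1.8-fold lower number from compound 2 to compound 4 (0.26 log units; that floor lies within the scatter), so the true size of this exchange stays unknown: the limit of > 64000 nM in this assay, at which 1 of the 4 values shown sits.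

The compounds shown leave open whether the nitrogen of dimethylamino is what counts here. An amino group, a methoxy group or a carboxylic acid at this place could read like compound 3 or like compound 4.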